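Side-chain swap on the shared core: outlook for compound 4

This account rests on a few compounds, and the source may have more. Where it says the series, first, only, none or still open, it means among the compounds named here.

Measured so far in an assay on HEK293 cells for binding affinity to Substance-K receptor (Rattus norvegicus), read by FRET, tested at 10 uM; on this read-out lower numbers stand for less inhibition and higher numbers for more inhibition at the one concentration tested (going by the name of the read-out):
compound 1, `N#CCN(Cc1ccccc1)Cc1ccc2ccccc2c1`: 0%
compound 2, `C#CCN(Cc1ccccc1)Cc1ccc2ccccc2c1`: 0%
compound 3, `O=C(O)CCCCN(Cc1ccccc1)Cc1ccc2ccccc2c1`: 0%

All three compounds share one core and differ only in the group on the saturated chain carbon bound to the amine nitrogen. Exchanging cyano for ethynyl gives no change at the digits printed from compound 1 to compound 2 (within the scatter); exchanging cyano for 3-carboxypropyl gives no change at the digits printed from compound 1 to compound 3 (within the scatter); and exchanging ethynyl for 3-carboxypropyl gives no change at the digits printed from compound 2 to compound 3 (within the scatter). Compound 3 thus stands level with compounds 1 and 2 at the digits shown, with no step among the three reaching beyond the scatter.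

Compound 4, `CCCCNC(=O)CN(Cc1ccccc1)Cc1ccc2ccccc2c1`, is the next member. It differs from compound 3 as follows: butylcarbamoyl in place of 3-carboxypropyl on a saturated chain carbon bound to an amine nitrogen

Every measured step at this position, small or large in group size, has left the read-out unchanged, so there is no basis for expecting a change beyond the scatter from compound 3 to compound 4 in this assay. The expected step is a number 2 percentage points higher from compound 3 to compound 4 (within the scatter). Compound 4 is estimated to give 2% in this assay, with a likely range from -8% to 15%.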

Compound 4, a percentage reported as inhibition, at one concentration (the size of the read-out at that concentration, not a potency): 0%
Compound 4: the middle estimate sits 2 percentage points above what was measured; low and high end bracket the measured number.
By their numbers in this assay, from the lowest: compounds 1, 2, 3 and 4 (each within the scatter of the next).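

In this assay the butylcarbamoyl group on the saturated chain carbon bound to an amine nitrogen gives no change at the digits printed from compound 3 to compound 4 (within the scatter) and no change at the digits printed from compound 2 to compound 4 (within the scatter) and also no change at the digits printed from compound 1 to compound 4 (within the scatter) in this series. The earlier compounds shown here covered only cyano, ethynyl and 3-carboxypropyl at this place, so the new information is that a chain carrying an amide also fails to separate from them, and compound 4 at 0% extends the flat picture to four side chains on the shared core. No measurement bearing on the reason for this flat read-out is available.

Since all four compounds sit at one level at a single concentration, the series gives no ranking of these groups and no sign yet that this position can move the read-out in either direction. Still open, on these data alone, is whether an amine, a hydroxyl group, a longer chain or a ring at this same place would give a read-out beyond the scatter, and whether any change to the shared core itself would do so.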